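The compounds below may be only part of what the source reports. "The series", "measured", "known", "first", "only" and "open" are said of these compounds alone.

Compound 1 `C[C@H]1O[C@]1(C)C(=O)C[C@@H]1[C@@]2(C)[C@@H](O)CCC(C)(C)[C@]2(O)CC[C@@]1(C)O` and compound 2 `C[C@@H]1O[C@@]1(C)C(=O)C[C@@H]1[C@@]2(C)[C@@H](O)CCC(C)(C)[C@]2(O)CC[C@@]1(C)O` have the same atoms and bonds and differ only in the configuration as drawn (the fact that compounds 1 and 2 differ only in the configuration as drawn). In a functional assay on A549 cells (Homo sapiens) for cytotoxicity, read by MTT assay, with a stated time of 24 h (a lower number here means a stronger inhibitor, a higher number a weaker inhibitor), compound 1 gives > 10000 nM, which is a limit of the assay and not a number. Compound 2 gives > 10000 nM, again only a limit, so it has no exact place on the scale: the limit of > 10000 nM in this assay, at which 2 of the 2 values shown sit. Compound 3 `C[C@@H]1O[C@@]1(C)C(=O)C[C@H]1[C@](C)(O)CC[C@@]2(O)C(C)(C)CCC[C@]12C` comes from compound 2 by one change: hydrogen in place of hydroxy on a saturated ring carbon. Within the data shown here, the only measured step is a step that the two limits leave unreadable from compound 1 to compound 2. It involves configuration, not the loss of a hydroxy group, and it has no readable size, so it offers no measured guide to this change. No step beyond the usual scatter, in either direction, is therefore expected in this assay. The expected change is a step that the limit leaves unreadable from compound 2 to compound 3. The estimate for compound 3 is 20000 nM, with an expected range from 6000 nM to 60000 nM.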

Compound 3, half-maximal inhibitory concentration: > 10000 nM
Compound 3 was reported as a limit (the forecaster's own chance of this, stated with the estimate: 80%); the middle value is on the limit's open side.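

No step can be read between compound 2 and compound 3, because both stand at a limit of the assay and not at a number: the limit of > 10000 nM in this assay, at which 3 of the 3 values shown sit.

The compounds shown leave open whether hydrogen in place of hydroxy, or the change in configuration, makes any difference in this assay, and what exact value any of the three compounds has there.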